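Dibenzylidene Piperazinedione Series: Aryl Swap Toward Compound 4

The source may report more compounds than this note shows. Statements on the series, on what has been measured and on what is new or still open speak of the compounds shown alone.

Three analogues of the shared core carry numbers or a qualitative result in a functional assay on BGC-823 cells (Homo sapiens) for cytotoxicity, read by CCK-8 assay, with a stated time of 72 h; on this read-out lower numbers stand for stronger inhibition and higher numbers for weaker inhibition. Compound 1 `C=CCn1c(=O)/c(=C\c2ccc(Cl)c(Cl)c2)[nH]c(=O)/c1=C\c1ccccc1` gives "not active" (no number reported) in this assay, a result that stands without a single number. Compound 2 `C=CCn1c(=O)/c(=C\c2cccc(F)c2)[nH]c(=O)/c1=C\c1ccccc1OC` gives 5600 nM in this assay, and compound 3 `COc1ccccc1/C=c1\c(=O)[nH]/c(=C/c2ccccc2Cl)c(=O)n1C` gives 300 nM in this assay. Of the two numbers, compound 2 is the higher one; compound 3 sits well below it, and that gap lies beyond the scatter.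

Compound 4 `C=CCn1c(=O)/c(=C\c2ccccc2OC)[nH]c(=O)/c1=C\c1ccccc1OC` is still to be measured in this assay. Relative to compound 2 it differs in one place: 2-methoxyphenyl in place of 3-fluorophenyl on a double-bonded chain carbon bound to an aromatic carbon. Among the measured compounds shown here, no measured pair isolates this change, so its size cannot be read from the data. Compound 3 shows that a 2-methoxyphenyl group on the shared core is compatible with a low number, but it also carries a different second aryl group, so its value cannot be transferred directly.

The step from compound 2 to compound 4 is expected to be small, probably within the scatter, with a slight lean toward a lower number: a 1.4-fold lower number from compound 2 to compound 4 (0.15 log units; within the scatter). Compound 4 is therefore estimated at 4000 nM in this assay, within a range of 1000 nM to 15000 nM.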

Compound 4, half-maximal inhibitory concentration: 13400 nM
For compound 4 the middle estimate is 3.4-fold (0.53 log units) below the measured one; low and high end bracket the measured number.
By their numbers in this assay, from the lowest: compound 3; then compound 2; then compound 4.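

In this assay, the change from 3-fluorophenyl to 2-methoxyphenyl on a double-bonded chain carbon bound to an aromatic carbon now has a measured size: a 2.4-fold higher number from compound 2 to compound 4 (0.38 log units; beyond the scatter). Among the compounds shown here, this is the first pair to isolate a change at this place, and it shows that the number responds to the aryl group there, with the step running toward weaker inhibition. Nothing available accounts for this rise.

A single pair leaves open whether the step keeps its direction and size when the rest of the molecule carries the other groups found in compound 3. It also leaves open how an aryl group bearing an amine or a carboxylic acid would read at this place.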